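The source may hold more compounds than are shown below. What is called first, only, known or untested is meant among the compounds shown, and "the series" means these compounds.

Three amides built on a shared dibromo-substituted core have been tested in an assay on isolated protein for inhibition of thiosulfate sulfurtransferase (Homo sapiens), with a stated time of 60 min, in the absence of a further agent; a higher number here means a weaker inhibitor, a lower number a stronger inhibitor. Compound 1 `O=C(Nc1cccc(Cl)c1)c1cc(Br)cc(Br)c1O` carries a free hydroxy group on the core and a chloro-substituted ring on the amide nitrogen. For compound 1 this assay returns only a limit, > 100000 nM, not a number. Compound 2 `COc1c(Br)cc(Br)cc1C(=O)Nc1ccccc1` has a methoxy group on the core and an unsubstituted ring on the amide nitrogen. For compound 2 this assay again gives only a limit, > 100000 nM. Compound 3 `COc1c(Br)cc(Br)cc1C(=O)Nc1ccc(Sc2nc3ccccc3s2)c(Cl)c1` keeps the methoxy group and adds a chloro group together with a large (1,3-benzothiazol-2-yl)sulfanyl group to the ring on the amide nitrogen. Going by the values given here, compound 3 also sits at a limit, > 100000 nM, so its standing among the three cannot be ranked, because the limit of > 100000 nM in this assay, at which 3 of the 3 values shown sit, describes where every value so far lies.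

Compound 4 `COc1c(Br)cc(Br)cc1C(=O)Nc1cccc(Cl)c1` differs from compound 3 by one change: hydrogen in place of (1,3-benzothiazol-2-yl)sulfanyl on an aromatic carbon. Among the compounds with values here, no measured pair shows this change, and compound 4 closely resembles compound 1 and compound 2. The step from compound 3 to compound 4 is therefore expected to be a step that the limit leaves unreadable from compound 3 to compound 4, with no movement beyond the scatter. For compound 4 the estimate in this assay is 150000 nM, within a range from 50000 nM to 500000 nM, most likely reported again only as a limit.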

Compound 4, half-maximal inhibitory concentration: > 100000 nM
Compound 4 ended at the assay's limit (the forecaster's own chance of this, stated with the estimate: 85%); the middle value is on the limit's open side.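

Going by these compounds alone, compound 4 also gives only a limit, so its steps from compound 1, compound 2 and compound 3 cannot be read, and no new step emerges: the limit of > 100000 nM in this assay, at which 4 of the 4 values shown sit. The compounds shown leave open which structural change, if any, would bring a measurable value in this assay at all.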